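A few compounds are considered here, and "the series" means these few. Any claim that something is new, unique, unknown or untested is made for them only; others in the source may bear on it.

Measured so far:
Compound 1 `COc1cc(/C=C/C(=O)O[C@H]2[C@H](OC[C@H]3O[C@@H](Oc4cc5c(cc4O)C[C@@H](C(=O)O)N5C(=O)/C=C/c4ccc(O)c(OC)c4)[C@H](O)[C@@H](O)[C@@H]3O)O[C@H](CO)[C@@H](O)[C@@H]2O)ccc1O`: 27600 nM
Compound 2 `COc1cc(/C=C/C(=O)N2c3cc(O[C@@H]4O[C@H](CO)[C@@H](O)[C@H](O)[C@H]4O)c(O)cc3C[C@H]2C(=O)O)ccc1O`: 35200 nM
Compound 3 `COc1cc(/C=C/C(=O)O[C@H]2[C@H](OC[C@H]3O[C@@H](Oc4cc5c(cc4O)C[C@@H](C(=O)O)N5C(=O)/C=C/c4ccc(O)cc4)[C@H](O)[C@@H](O)[C@@H]3O)O[C@H](CO)[C@@H](O)[C@@H]2O)ccc1O`: 29100 nM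

In a physicochemical assay, with a stated time of 30 min (on this read-out higher numbers stand for an effect only at larger amounts of compound and lower numbers for an effect already at smaller amounts), compound 3 gives the second highest of the three numbers, and its gaps to compound 1 and to compound 2 both lie within the scatter, so the three cannot be told apart. Compound 4 `O=C(/C=C/c1ccc(O)c(O)c1)O[C@H]1[C@H](OC[C@H]2O[C@@H](Oc3cc4c(cc3O)C[C@@H](C(=O)O)N4C(=O)/C=C/c3ccc(O)cc3)[C@H](O)[C@@H](O)[C@@H]2O)O[C@H](CO)[C@@H](O)[C@@H]1O` differs from compound 3 in one place: hydrogen in place of methyl on an oxygen on an aromatic ring. Among the measured compounds shown here, the single measured step, a 1.1-fold higher number from compound 1 to compound 3 (0.02 log units; within the scatter), put hydrogen in place of methoxy on an aromatic carbon and stayed within the scatter. For the measured compounds named here, no measured pair shows a methyl leaving an oxygen on an aromatic ring. Going by the values given here, with that one small step as the only guide, compound 4 is expected to show no shift beyond the scatter, a 1.1-fold lower number from compound 3 to compound 4 (0.03 log units; within the scatter). Compound 4 is therefore estimated at 27000 nM, within 14000 nM to 52000 nM.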

Compound 4, half-maximal effective concentration: 15300 nM
For compound 4 the middle estimate is 1.8-fold (0.25 log units) above the measured one; measured number inside the range.
By their numbers in this assay, from the lowest: compounds 4, 1, 3 and 2 (each within the scatter of the next, the first and the last beyond it).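

Among the compounds shown here, this is the first measured case of a methyl leaving an oxygen on an aromatic ring: in this assay, methoxy to hydroxy on the 2-(4-hydroxy-3-methoxyphenyl)ethenyl group gives a 1.9-fold lower number from compound 3 to compound 4 (0.28 log units; within the scatter). So at this position, a free hydroxy in place of methoxy cannot be told apart from the methoxy on this read-out. Nothing measured here bears on what lies behind this small step. Still open, from the compounds shown here alone, is whether a longer chain on this oxygen, such as ethoxy, would give a step beyond the scatter. The same holds for an amine in place of the hydroxy.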